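Swapping the dichlorophenyl on the piperazine for ethoxyphenyl

This account rests on a few compounds, and the source may have more. Where it says the series, first, only, none or still open, it means among the compounds named here.

Compound 1 `Cc1nc(-c2ccccc2)c(C(=O)N2CCN(c3ccc(Cl)c(Cl)c3)CC2)o1`: 124 nM
Compound 2 `Cc1nc(-c2ccc(F)cc2)c(C(=O)N2CCN(c3cc(Cl)cc(Cl)c3)CC2)o1`: 52.1 nM

Of the compounds shown here, two have been measured in a functional assay on HL-60 cells (Homo sapiens) for inhibition, read by MTT assay, with a stated time of 72 h; a higher number here means a weaker inhibitor, a lower number a stronger inhibitor. Compound 1 gives 124 nM, the highest of the two numbers; compound 2 gives 52.1 nM, a lower number, and the gap between them lies beyond the scatter. Among the compounds with values here, no pair among the measured compounds differs in only one place, so no single-change step is available to guide the next compound.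

Compound 3 `CCOc1cccc(N2CCN(C(=O)c3oc(C)nc3-c3ccccc3)CC2)c1` departs from compound 1 in one place: 3-ethoxyphenyl in place of 3,4-dichlorophenyl on an amine nitrogen in a ring. Within the data shown here, no measured pair shows what this exchange does, so the expectation rests on compound 1 alone as the starting point. The step of a 2.4-fold higher number from compound 1 to compound 3 (0.38 log units; beyond the scatter) is expected to raise the number, that is to weaken inhibition, by more than the scatter, though the direction remains uncertain. Compound 3 is therefore estimated at 300 nM, with a range from 80 nM to 1500 nM.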

Compound 3, half-maximal inhibitory concentration: 151 nM
For compound 3 the middle estimate is 2.0-fold (0.30 log units) above the measured one; the range from low to high includes it.
By their numbers in this assay, from the lowest: compound 2; then compounds 1 and 3 (each within the scatter of the next).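

The exchange gives a 1.2-fold higher number from compound 1 to compound 3 (0.09 log units; within the scatter) in this assay, the first single-change step available, and it lies within the scatter. On this amine nitrogen in a ring, 3-ethoxyphenyl therefore stands in for 3,4-dichlorophenyl with no change that can be told from the scatter, even though both chlorines are gone and an oxygen and a hydrogen-bond acceptor have entered. No measured evidence offers a reason for this result.

From the compounds shown here alone, what remains open is whether other groups on this nitrogen, such as 3-methoxyphenyl, unsubstituted phenyl or a pyridine ring, would also read alike. Going by these compounds, it is also open whether the same exchange would give a similar step on the core of compound 2.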